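Aortic relaxation series: ring chlorination of compound 1

This account rests on a few compounds, and the source may have more. Where it says the series, first, only, none or still open, it means among the compounds named here.

Measured so far:
- Compound 1 `CC(C)C(C)NC1=NS(=O)(=O)c2cccnc2N1`: in a functional assay (aorta) with Rattus norvegicus as the target (on this read-out lower numbers stand for an effect already at smaller amounts and higher numbers for an effect only at larger amounts of compound), compound 1 gives > 300 uM, a limit of the assay.
- Compound 2 `CC(NC1=NS(=O)(=O)c2cccnc2N1)C(C)(C)C`: in this assay compound 2 gives > 300 uM, also a limit.

Compound 1 therefore stands only at an assay limit; the step that the two limits leave unreadable from compound 1 to compound 2 is unreadable because of the limit of > 300 uM in this assay, at which 2 of the 2 values shown sit. Compound 3 `CC(C)C(C)NC1=NS(=O)(=O)c2cc(Cl)cnc2N1` differs from compound 1 by chloro in place of hydrogen on an aromatic carbon. Among the compounds with values here, no measured step touches the aromatic ring, so nothing here supports an expectation of a change beyond the scatter. Compound 3 is expected to give about 300 uM (range 30 uM to 3000 uM), meaning an estimated step of a number no higher from compound 1 to compound 3 (the limit leaves the size open).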

Compound 3, concentration for half-maximal effect: 49.3 uM
Compound 3: middle estimate off by 6.1-fold (0.78 log units), on the high side; low and high end bracket the measured number.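

In this assay, chloro in place of hydrogen on an aromatic carbon, two atoms from the ring nitrogen, gives an at least 6.0-fold lower number from compound 1 to compound 3 (0.78 log units; beyond the scatter), the only change shown that leads to a value clear of the assay limit. This aromatic carbon is therefore a place where the exchange of hydrogen for one heavy atom can be read, whereas the chain step stays unreadable: the limit of > 300 uM in this assay, at which 2 of the 3 values shown sit.

From the compounds shown here alone, whether this step is particular to chloro remains open, as does the outcome with a methoxy group or an amine on the same carbon. Also open, going by these compounds, is whether chloro gives a comparable step on the core of compound 2.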